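Compound 4: 2,4-dimethylphenyl replaces 4-chlorophenyl on nitrogen

A few compounds are considered here, and "the series" means these few. Any claim that something is new, unique, unknown or untested is made for them only; others in the source may bear on it.

Three compounds share one core and differ only in the group carried on an aromatic nitrogen. Compound 1 `Oc1cc(C(F)(F)F)ccc1-c1nc(-c2ccccc2O)n(-c2ccc(Cl)cc2)n1` carries a 4-chlorophenyl there; in a functional assay on PC-12 cells (Rattus norvegicus) for cytotoxicity, read by MTT assay, with stated times of 2 h and 24 h, tested at 1 uM (on this read-out higher numbers stand for a stronger effect at the one concentration tested and lower numbers for a weaker effect), compound 1 gives 68%. Compound 2 `COc1ccc(-n2nc(-c3ccc(C(F)(F)F)cc3O)nc2-c2ccccc2O)cc1` gives 69% in this assay, and compound 3 `Oc1cc(C(F)(F)F)ccc1-c1nc(-c2ccccc2O)n(-c2ccccc2Cl)n1` gives 70.1% in this assay. Compound 1 holds the lowest of the three numbers, but its gap to compound 2 is a number 1 percentage points higher from compound 1 to compound 2 (within the scatter) and its gap to compound 3 is a number 2.1 percentage points higher from compound 1 to compound 3 (within the scatter), both within the scatter, so no order among the three can be read. Between compound 2 and compound 3 the step is a number 1.1 percentage points higher from compound 2 to compound 3 (within the scatter), also within the scatter.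

Compound 4 `Cc1ccc(-n2nc(-c3ccc(C(F)(F)F)cc3O)nc2-c2ccccc2O)c(C)c1` has not yet been measured. It differs from compound 1 as follows: 2,4-dimethylphenyl in place of 4-chlorophenyl on an aromatic nitrogen. For the measured compounds named here, the steps that bear on this change are those that alter the group on the same aromatic nitrogen: methoxy in place of chloro on an aromatic carbon gave a number 1 percentage points higher from compound 1 to compound 2 (within the scatter), and 2-chlorophenyl in place of 4-chlorophenyl gave a number 2.1 percentage points higher from compound 1 to compound 3 (within the scatter). Neither moved the number beyond the scatter, so the step expected here is a number 1.5 percentage points higher from compound 1 to compound 4 (within the scatter), none beyond the scatter. Compound 4 is therefore estimated to give about 69.5% in this assay, within a range from 62% to 77%.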

Compound 4, a percentage reported as activity, at one concentration (the size of the read-out at that concentration, not a potency): 73.7%
Compound 4: the middle estimate sits 4.2 percentage points below what was measured; the measured number falls inside the stated range.
By their numbers in this assay, from the lowest: compounds 1, 2, 3 and 4 (each within the scatter of the next).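

Placing the 2,4-dimethylphenyl group on this aromatic nitrogen in this assay gives a number 5.7 percentage points higher from compound 1 to compound 4 (within the scatter) against the 4-chlorophenyl group, a number 3.6 percentage points higher from compound 3 to compound 4 (within the scatter) against the 2-chlorophenyl group and a number 4.7 percentage points higher from compound 2 to compound 4 (within the scatter) against the 4-methoxyphenyl group. The earlier compounds shown here each carried a single chloro or methoxy group on the phenyl ring, whereas compound 4 carries two methyl groups and has neither chlorine nor oxygen in this group, and the read-out still stays within the scatter of all three. Nothing measured here accounts for this absence of a clear step.

As far as these compounds go, all four groups at this position are substituted phenyl rings, so it remains open whether a group of another kind, such as a saturated alkyl chain, a benzyl group or a phenyl ring bearing an amine or a carboxylic acid, would move the number beyond the scatter. From the compounds shown here alone, the hydroxyl and trifluoromethyl groups are the same in all four compounds, so what changes there would do also stays open.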